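Swapping the Aryl Ester Group for an Anilino Group

This account rests on a few compounds, and the source may have more. Where it says the series, first, only, none or still open, it means among the compounds named here.

Compound 1 `CC1=CC[C@H](C(C)C)c2cc(C)c(OC(=O)c3cccc(C)c3)cc21` was tested in a functional assay on HCT-15 cells (Homo sapiens) for antiproliferative activity, read by sulforhodamine B assay, with a stated time of 48 h, tested at 50 uM (on this read-out lower numbers stand for less inhibition and higher numbers for more inhibition at the one concentration tested (going by the name of the read-out)), where compound 1 gives 5.3%. Among the three measured compounds this is the lowest number. The nearest is compound 3 `CC1=CC[C@H](C(C)C)c2cc(C)c(OC(=O)c3cccc(C(F)(F)F)c3)cc21`, which in this assay gives 15%; the step of a number 9.7 percentage points higher from compound 1 to compound 3 (within the scatter) corresponds to a trifluoromethyl in place of methyl on an aromatic carbon. Furthest is compound 2 `Cc1cc2c(C(C)C)ccc(C)c2cc1OC(=O)c1ccc(C(F)(F)F)cc1`, built on a different core, which in this assay gives 55.6%, a number that lies beyond the scatter from compound 1.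

Compound 4 `CC1=CC[C@H](C(C)C)c2cc(C)c(OC(=O)Nc3ccccc3)cc21` differs from compound 1 in one place: anilino in place of 3-methylphenyl on a carbonyl carbon. For the measured compounds named here, none of the measured steps changes the group on the carbonyl carbon in this way; the only single-point step that was measured, a number 9.7 percentage points higher from compound 1 to compound 3 (within the scatter), alters a substituent on the aromatic ring and stays within the scatter. There is therefore no measured basis for expecting a step in this assay beyond the scatter in either direction, and the starting point is already near the bottom of the scale. Compound 4 is expected to give about 10% in this assay, within a range of 0% to 30%. The estimated step of a number 4.7 percentage points higher from compound 1 to compound 4 (within the scatter) is thus expected to remain within the usual scatter.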

Compound 4, a percentage reported as inhibition, at one concentration (the size of the read-out at that concentration, not a potency): 92%
Estimate against measurement, compound 4: 82 percentage points below, and the stated range ends below it.
By their numbers in this assay, from the lowest: compounds 1 and 3 (each within the scatter of the next); then compound 2; then compound 4.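

In this assay, the step of a number 86.7 percentage points higher from compound 1 to compound 4 (beyond the scatter) shows that the group on the carbonyl carbon is a place where this read-out can move a long way, something the earlier step on the aromatic ring, a number 9.7 percentage points higher from compound 1 to compound 3 (within the scatter), gave no sign of. The change is also a small one on paper: both groups have 7 heavy atoms and one six-membered aromatic ring of carbon only, and the differences in the count are a nitrogen in place of a carbon and the 1 hydrogen-bond donor that anilino brings, so a large shift here does not need a larger group. Nothing available ties this jump to any particular property of the anilino group, so its origin remains unexplained.

The compounds shown leave open whether the amide hydrogen matters, a question that N-methylanilino in the same place could address, and whether the aromatic ring must sit directly on the nitrogen, which benzylamino could test. They also leave open whether anilino on the core of compound 2, or a trifluoromethyl group on the anilino ring, would give a similar number.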